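Three Measured Compounds and a Hydroxy Swap

The source may report more compounds than this note shows. Statements on the series, on what has been measured and on what is new or still open speak of the compounds shown alone.

Measured so far in a functional assay on HOP-62 cells (Homo sapiens) for inhibition, read by sulforhodamine B assay; a higher number here means a weaker inhibitor of growth, a lower number a stronger inhibitor of growth:
compound 1 `Cc1ccc2[nH]c(-c3ccc(-c4ccc(-c5cccc(Cl)c5)cc4)cc3)nc2c1` gives 2740 nM
compound 2 `Cc1ccc2[nH]c(-c3ccc(-c4ccc(-c5ccc(F)cc5)cc4)cc3)nc2c1` gives 33500 nM
compound 3 `Cc1ccc2[nH]c(-c3ccc(-c4ccc(-c5ccc(C(F)(F)F)cc5)cc4)cc3)nc2c1` gives 24200 nM

Compound 3 stands within the scatter of compound 2 and well above compound 1. The next structure, compound 4 `Cc1ccc2[nH]c(-c3ccc(-c4ccc(-c5ccc(O)cc5)cc4)cc3)nc2c1`, has hydroxy in place of trifluoromethyl on an aromatic carbon, para to a large group (hydroxy in place of trifluoromethyl on an aromatic carbon). The nearest guide is the swap at that same place, which gave a 1.4-fold lower number from compound 2 to compound 3 (0.14 log units; within the scatter). The larger steps, a 12-fold higher number from compound 1 to compound 2 (1.09 log units; beyond the scatter) and an 8.8-fold higher number from compound 1 to compound 3 (0.95 log units; beyond the scatter), both start from 3-chlorophenyl, so they bear less directly on this change. Within the data shown here, no hydroxy compound has been measured, so the range stays wide. The expected step is a 1.6-fold lower number from compound 3 to compound 4 (0.21 log units; within the scatter) and no change beyond the scatter is expected. Compound 4 is estimated at 15000 nM with an expected range of 4000 nM to 50000 nM in this assay.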

Compound 4, concentration for 50% growth inhibition: 41200 nM
Compound 4: the middle estimate sits 2.7-fold (0.44 log units) below what was measured; measured number inside the range.
By their numbers in this assay, from the lowest: compound 1; then compounds 3, 2 and 4 (each within the scatter of the next).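

In this assay, hydroxy counts a hydrogen-bond donor where trifluoromethyl and fluoro have none, yet it stands within the scatter of both (a 1.7-fold higher number from compound 3 to compound 4 (0.23 log units; within the scatter); a 1.2-fold higher number from compound 2 to compound 4 (0.09 log units; within the scatter)). So far, then, three quite different groups at this place, para to a large group, give numbers that cannot be told apart. Compound 1 with its 3-chlorophenyl remains clearly apart (a 15-fold higher number from compound 1 to compound 4 (1.18 log units; beyond the scatter)), and no evidence here explains any of these numbers.

On these data alone, whether an amine or a carboxylic acid at this place would also stay within the scatter remains open. So does whether chloro, para to a large group, would match compound 1 or join the other three.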